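Benzylpurine pair: removing the second chloro from compound 2

The compounds below may be only part of what the source reports. "The series", "measured", "known", "first", "only" and "open" are said of these compounds alone.

Measured so far:
compound 1 `ClCc1ccc(Cn2cnc3c(Cl)ncnc32)cc1`: 4360 nM
compound 2 `ClCc1ccccc1Cn1cnc2c(Cl)nc(Cl)nc21`: 2180 nM

In a functional assay on SK-MEL-2 cells (Homo sapiens) for cytotoxicity, read by sulforhodamine B assay, with a stated time of 48 h (on this read-out lower numbers stand for stronger inhibition of growth and higher numbers for weaker inhibition of growth), compound 2 gives 2180 nM, the lowest of the two numbers recorded; compound 1 gives 4360 nM, and the two lie within the scatter of each other, so no order between them is claimed. Compound 3 `ClCc1ccccc1Cn1cnc2c(Cl)ncnc21` is not yet measured in this assay. It differs from compound 2 in hydrogen in place of chloro on an aromatic carbon. For the measured compounds named here, no measured pair differs in this single place, so there is no measured step to lean on. For a change that removes one heavy atom from the core, the number for compound 3 is expected to stay near that of compound 2 or drift somewhat higher, a step of a 1.6-fold higher number from compound 2 to compound 3 (0.21 log units; within the scatter) in this assay that may well stay within the scatter. Compound 3 is therefore estimated at 3500 nM, with an expected range from 1200 nM to 10000 nM.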

Compound 3, concentration for 50% growth inhibition: 2750 nM
Estimate against measurement, compound 3: 1.3-fold (0.10 log units) above; the range from low to high includes it.
By their numbers in this assay, from the lowest: compounds 2, 3 and 1 (each within the scatter of the next).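

In this assay, for the compounds shown here, hydrogen in place of chloro on an aromatic carbon between two ring nitrogen atoms gives a 1.3-fold higher number from compound 2 to compound 3 (0.10 log units; within the scatter), the first step that can be read at a single position. This chloro is therefore not required for growth inhibition in this range of numbers, since its removal leaves a difference that cannot be told from the scatter. No measurement shown here offers an explanation for this result.

From the compounds shown here alone, it remains open whether an amine or a methoxy group at this position would move the number beyond the scatter. Also open, going by these compounds, is whether replacing the other chloro on the same ring, the one meta to this position, with an amine would leave the number similarly close.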